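The compounds below may be only part of what the source reports. "The series", "measured", "known", "first", "only" and "open" are said of these compounds alone.

Working notes on the series, all numbers from a functional assay on CHO-K1 cells for antagonist activity at C-X-C chemokine receptor type 3 (Homo sapiens), read by FLIPR, with a stated time of 10 min; a higher number here means a weaker inhibitor, a lower number a stronger inhibitor.

Compound 1 `O=C(Nc1ncccc1N1CCN(C(=O)Cn2cnc3cccnc32)CC1)c1cccc(Cl)c1` gives 177 nM in this assay. Compound 2 `CCOc1ncc(-c2nc(C(F)(F)F)sc2N2CCN(C(=O)Cn3cnc4ccccc43)[C@H](C)C2)cn1` gives 2 nM. Compound 3 `Cc1nc(C)n(CC(=O)N2CCN(c3sc(C(F)(F)F)nc3-c3cnc(OC4CCC4)nc3)C[C@H]2C)n1` gives 4 nM. Compound 3 thus stands second highest of the three numbers: its nearest neighbour is compound 2, whose number is lower by an amount within the usual scatter, so the two are not distinguished here; the furthest is compound 1, whose number is higher by an amount well beyond the scatter.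

Compound 4 `Cc1nc(C)n(CC(=O)N2CCN(c3sc(C(F)(F)F)nc3-c3cnc(N4CCCC4)nc3)C[C@H]2C)n1` is the next point. It differs from compound 3 by pyrrolidin-1-yl in place of cyclobutyloxy on an aromatic carbon. Within the data shown here, no pair of measured compounds differs in exactly one place, so there is no measured step to lean on for this change. The expectation for compound 4 is a step of a 1.3-fold higher number from compound 3 to compound 4 (0.10 log units; within the scatter), which is within the scatter, with no clear direction. Compound 4 is therefore estimated at 5 nM, with a range from 1.5 nM to 15 nM.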

Compound 4, half-maximal inhibitory concentration: 3.5 nM
For compound 4 the middle estimate is 1.4-fold (0.15 log units) above the measured one; measured number inside the range.
By their numbers in this assay, from the lowest: compounds 2, 4 and 3 (each within the scatter of the next); then compound 1.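

Among these compounds, the first measured change at this position, on the aromatic carbon between two ring nitrogen atoms, swaps cyclobutyloxy for pyrrolidin-1-yl and gives, in this assay, a 1.1-fold lower number from compound 3 to compound 4 (0.06 log units; within the scatter). Among the compounds shown here, the two groups, an oxygen-linked four-membered carbon ring and a nitrogen-linked five-membered ring, are therefore not distinguished here, and the change leaves the compound in the same range of numbers, which the earlier compounds could not show without a measured step. No measurement on these groups bears on why the two are not distinguished.

This single pair does not show how far that tolerance extends, as both groups are cyclic and carry the same count of heavy atoms. A carboxylic acid, a primary amine or a longer open chain at this carbon remains untested among the compounds shown.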